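A few compounds are considered here, and "the series" means these few. Any claim that something is new, unique, unknown or untested is made for them only; others in the source may bear on it.

The measured compounds and their values:

Compound 1, `CS(=O)(=O)c1cc(C(=O)N=C(N)N)c(Cl)cc1Cl`, gives 140 nM.
Compound 2, `Cc1c(C(=O)N=C(N)N)cc(S(C)(=O)=O)c(Cl)c1[N+](=O)[O-]`, gives 44 nM.
Compound 3, `Cc1cc(-c2ccc(Cl)cc2)c(S(C)(=O)=O)cc1C(=O)N=C(N)N`, gives 45 nM.

All three were tested in a functional assay for inhibition of sodium/hydrogen exchanger (Oryctolagus cuniculus); on this read-out lower numbers stand for stronger inhibition and higher numbers for weaker inhibition. Compound 3 stands second highest among the three numbers. Its nearest neighbour is compound 2, whose number lies within the usual scatter of compound 3, so the two cannot be told apart. Its furthest neighbour is compound 1, whose number is higher by a margin beyond the scatter, so compound 1 inhibits less strongly than compound 3.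

Compound 4, `Cc1cc(OC2CCCC2)c(S(C)(=O)=O)cc1C(=O)N=C(N)N`, has not yet been measured. It differs from compound 3 in one place: cyclopentyloxy in place of 4-chlorophenyl on an aromatic carbon. The cyclopentyloxy group sits on an aromatic carbon of the shared core, ortho to the methylsulfonyl group. Among the measured compounds shown here, no measured pair shows this kind of exchange, so the size of the step is uncertain. The expected step is a 1.8-fold higher number from compound 3 to compound 4 (0.25 log units; within the scatter), a modest move toward a higher number that may stay within the scatter. Compound 4 is estimated at 80 nM, with a range from 25 nM to 260 nM.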

Compound 4, half-maximal inhibitory concentration: 27 nM
Compound 4: the middle estimate sits 3.0-fold (0.47 log units) above what was measured, within the range that was stated.
By their numbers in this assay, from the lowest: compounds 4, 2 and 3 (each within the scatter of the next); then compound 1.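

In this assay, putting cyclopentyloxy in place of 4-chlorophenyl, on the aromatic carbon ortho to the methylsulfonyl group, gives a 1.7-fold lower number from compound 3 to compound 4 (0.22 log units; within the scatter), so the two compounds cannot be told apart. Among the compounds shown here, this is the first direct view of this position: it holds either a six-membered aromatic ring of carbon only or a five-membered non-aromatic ring attached through an oxygen, with no difference beyond the scatter. Nothing measured here accounts for this result.

Both groups carry a ring, so the compounds shown leave open what a small methoxy, a primary amine or a carboxylic acid at this position would give in this assay. From the compounds shown here alone, it also remains open whether this exchange would give a step of similar size if other groups on the shared core were changed.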